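Swapping an acetamido for bromo on a hydroxamic acid series

This account rests on a few compounds, and the source may have more. Where it says the series, first, only, none or still open, it means among the compounds named here.

Measured compounds:
- compound 1, `O=C(CCC1=CCCN(CCCCc2ccc(-c3ccccc3)cc2)C1=O)NO`, 4560 nM
- compound 2, `CC(=O)Nc1ccc(CN2CCC=C(CCC(=O)NO)C2=O)cc1`, "not determined" (no result reported)
- compound 3, `O=C(CCC1=CCCN(Cc2ccc3ccccc3c2)C1=O)NO`, "not determined" (no result reported)

In a functional assay on HCT-15 cells (Homo sapiens) for inhibition, read by sulforhodamine B assay (on this read-out lower numbers stand for stronger inhibition of growth and higher numbers for weaker inhibition of growth), compound 1 gives 4560 nM. For compound 2 no result is reported, and compound 3 also has no number, so compound 2 cannot be placed against any neighbour; only compound 1 offers a numerical anchor. Compound 4, `O=C(CCC1=CCCN(Cc2ccc(Br)cc2)C1=O)NO`, differs from compound 2 in one place: bromo in place of acetamido on an aromatic carbon. For the measured compounds named here, no measured step between two compounds exists here, so the size of this change cannot be read from the data. Taking compound 1 at 4560 nM as the only reference, compound 4 is expected to land in the same broad range, estimated at 4000 nM with a likely span from 1000 nM to 16000 nM.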

Compound 4, concentration for 50% growth inhibition: 1720 nM
The estimate for compound 4 lay 2.3-fold (0.37 log units) above the measured number, and the stated range covers the measured number.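

In this assay, for the compounds shown here, compound 2 has no single number, so no step from it to compound 4 can be read. What swapping acetamido for bromo does to growth inhibition stays open, and no other data shown bear on it.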